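The source may report more compounds than this note shows. Statements on the series, on what has been measured and on what is new or still open speak of the compounds shown alone.

Three compounds share one core and differ only in the group carried on a nitrogen on an aromatic ring. Compound 1 `C=CCN(c1nccc(-c2c(OC)cc(OC)cc2OC)n1)C(C1CC1)C1CC1` gives 100 nM in an assay on CHO cells for displacement of a labelled ligand from corticotropin-releasing factor receptor 1 (Homo sapiens); on this read-out lower numbers stand for stronger inhibition and higher numbers for weaker inhibition. Compound 2 `CCCN(c1nccc(-c2c(OC)cc(OC)cc2OC)n1)[C@@H](c1ccccc1)C1CC1` gives 240 nM in this assay, and compound 3 `CCCN(c1nccc(-c2c(OC)cc(OC)cc2OC)n1)C1(c2ccoc2)CC1` gives 700 nM. On these numbers compound 2 stands second highest of the three: compound 1 shows a lower number, while compound 3 shows a higher one through a 2.9-fold higher number from compound 2 to compound 3 (0.46 log units; beyond the scatter).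

Compound 4 `CCCN(c1nccc(-c2c(OC)cc(OC)cc2OC)n1)C1CCCC1` has not yet been measured. Its difference from compound 2 is cyclopentyl in place of cyclopropyl(phenyl)methyl on a nitrogen on an aromatic ring. Among the measured compounds shown here, the one measured step that bears on it is the exchange of the group on the same nitrogen, a 2.9-fold higher number from compound 2 to compound 3 (0.46 log units; beyond the scatter), which moved the number upward by a modest amount. For the measured compounds named here, the entering cyclopentyl is a smaller group than the one it replaces, and no measured compound shows what such a group does here, so the expectation is uncertain. A step in the weakening direction, beyond the scatter, is expected: a 2.9-fold higher number from compound 2 to compound 4 (0.46 log units; beyond the scatter). Compound 4 is estimated at 700 nM, within a range from 200 nM to 2500 nM.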

Compound 4, inhibition constant: 2200 nM
Beside the measured number, compound 4's estimate is 3.1-fold (0.50 log units) below it; low and high end bracket the measured number.
By their numbers in this assay, from the lowest: compound 1; then compound 2; then compound 3; then compound 4.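

In this assay, among the compounds shown here, this position proves far more sensitive than the earlier compounds suggested: cyclopentyl in place of cyclopropyl(phenyl)methyl gives a 9.2-fold higher number from compound 2 to compound 4 (0.96 log units; beyond the scatter) and is a clearly larger step than the exchange for 1-(furan-3-yl)cyclopropyl. Cyclopentyl also falls short of that furan-bearing group, with a 3.1-fold higher number from compound 3 to compound 4 (0.50 log units; beyond the scatter) as the step. Among these three compounds with the same propyl group on the nitrogen, the two whose exchanged group carries an aromatic ring give lower numbers than compound 4, whose group has none.

Phenyl and cyclopropyl leave together in this change, so it remains open which of them counts; a benzyl group on the same nitrogen would keep only the phenyl, and a cyclopropylmethyl group only the cyclopropyl. No independent evidence on the reason for these steps is available here.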